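Cyclopentyloxy in place of ethoxy on a catechol-bearing quinoline

The source may hold more compounds than are shown below. What is called first, only, known or untested is meant among the compounds shown, and "the series" means these compounds.

Compound 1 `CCOc1cc(-c2ccc(O)c(O)c2)nc2ccccc12`: 20 nM
Compound 2 `COc1ccc(/C=C/C(=O)c2cc(C)c(C)cc2O)cc1OCc1ccccc1`: "not active" (no number reported)
Compound 3 `CC(C)Oc1cc(-c2ccc(N(C)C)cc2)nc2ccccc12`: 50 nM

Of the compounds shown here, three have been tested in a functional assay on HT-22 cells (Mus musculus), read by MTT assay, with a stated time of 24 h; a lower number here means that less compound is needed, a higher number that more compound is needed for the effect. Compound 1 gives 20 nM in this assay. Compound 3 gives 50 nM, a higher number than compound 1, and the gap between the two lies beyond the usual scatter of this assay, so compound 1 stands with the lowest number of the two numbers reported. Compound 2 is reported as "not active" (no number reported), with no number attached, and therefore cannot be ranked against the other two. Among the measured compounds shown here, no pair among the measured compounds differs in a single place, so no single-change step is available for comparison.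

Compound 4 `Oc1ccc(-c2cc(OC3CCCC3)c3ccccc3n2)cc1O` differs from compound 1 in one place: cyclopentyl in place of ethyl on an oxygen on an aromatic ring. The shared core of compound 1 and its catechol-bearing ring are kept; only the group on the oxygen is altered. For the measured compounds named here, with no measured step of this kind to lean on, the expectation for compound 4 rests on compound 1 alone, whose value is 20 nM. The step from compound 1 to compound 4 is expected to be small, at or near the scatter, and if anything toward a higher number, a 1.5-fold higher number from compound 1 to compound 4 (0.18 log units; within the scatter). Compound 4 is therefore estimated to give 30 nM, with a range from 10 nM to 100 nM.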

Compound 4, half-maximal effective concentration: 7 nM
Compound 4: middle estimate off by 4.3-fold (0.63 log units), on the high side; measured number below the stated range.
By their numbers in this assay, from the lowest: compound 4; then compound 1; then compound 3.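

Among the compounds shown here, the first single-change step in this set falls on the oxygen on an aromatic ring, where cyclopentyl in place of ethyl gives a 2.9-fold lower number from compound 1 to compound 4 (0.46 log units; beyond the scatter) in this assay. The change is modest, but it shows that with the shared core and the catechol-bearing ring kept, this position accepts a five-membered non-aromatic ring of carbon only, and that the number moves down rather than up. The data shown include nothing that bears on why this exchange lowers the number.

This single step cannot tell whether the ring itself matters or simply the larger carbon group, a question that an open chain such as pentyl, or a smaller ring such as cyclopropyl, on the same oxygen would address. It also leaves open how a group carrying an amine or a carboxylic acid at this position would read in this assay, and whether the same exchange would lower the number on a compound without the catechol-bearing ring.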